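Ring Enlargement at the Amino Substituent of Compound 2

The source may report more compounds than this note shows. Statements on the series, on what has been measured and on what is new or still open speak of the compounds shown alone.

Compound 2, with structure `OC[C@H]1OC(n2c(NC3CCCC3)nc3c(SCc4ccccc4)ncnc32)[C@H](O)[C@@H]1O`, gives 0.64 nM in an assay on cell membranes for binding affinity to Equilibrative nucleoside transporter 1 (Homo sapiens) (on this read-out higher numbers stand for weaker inhibition and lower numbers for stronger inhibition), which is the lowest of the two numbers measured; its nearest neighbour is compound 1, structure `CCCNc1nc2c(SCc3ccccc3)ncnc2n1C1O[C@H](CO)[C@@H](O)[C@H]1O`, which gives 5.3 nM in this assay. Going by the values given here, the single measured step that bears on the question is an 8.3-fold lower number from compound 1 to compound 2 (0.92 log units; beyond the scatter), a move from an open chain to a five-membered ring on the same nitrogen. Compound 3, structure `OC[C@H]1OC(n2c(NC3CCCCC3)nc3c(SCc4ccccc4)ncnc32)[C@H](O)[C@@H]1O`, differs from compound 2 only in this way: cyclohexyl in place of cyclopentyl on a nitrogen on an aromatic ring. Among the compounds with values here, no measured pair shows a ring of one size against a ring of the next size, so the expectation rests on compound 2 alone, and compound 3 is expected to stay close to it, with a step of a 1.1-fold lower number from compound 2 to compound 3 (0.03 log units; within the scatter) that is not expected to pass beyond the scatter. Compound 3 is therefore estimated to give 0.6 nM in this assay, within a range of 0.2 nM to 2 nM.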

Compound 3, inhibition constant: 0.94 nM
Compound 3: the middle estimate sits 1.6-fold (0.19 log units) below what was measured, within the range that was stated.
By their numbers in this assay, from the lowest: compounds 2 and 3 (each within the scatter of the next); then compound 1.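

Going from the five-membered to the six-membered ring on this nitrogen leaves the number in this assay within the scatter (a 1.5-fold higher number from compound 2 to compound 3 (0.17 log units; within the scatter)), so cyclopentylamino and cyclohexylamino cannot be told apart at this position. The advantage over the open chain seen earlier is therefore not confined to one ring size: the cyclohexyl group also stands clear of propyl (a 5.6-fold lower number from compound 1 to compound 3 (0.75 log units; beyond the scatter)), and among these compounds no result goes against that pattern. Nothing available here explains why either ring differs from the propyl chain.

The compounds shown leave open how far ring size can grow before the number changes beyond the scatter, as a cycloheptyl group would test. They also leave open whether a branched chain such as isopropyl, or a ring carrying an oxygen atom such as tetrahydropyranyl, would match the two carbon rings on this nitrogen.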